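Hydroxyl shift on the aryl ketone in a cytotoxicity series

The source may report more compounds than this note shows. Statements on the series, on what has been measured and on what is new or still open speak of the compounds shown alone.

Three analogues sharing one core have been run in a toxicity assay on MCF-10A cells (Homo sapiens) for cytotoxicity, read by MTT assay, with a stated time of 48 h; on this read-out lower numbers stand for stronger inhibition and higher numbers for weaker inhibition. Compound 1 `Cc1ccc(C(=O)/C=C/c2ccc3c(c2)B(O)OC3)cc1` gives 8300 nM. Compound 2 `Nc1ccc(C(=O)/C=C/c2ccc3c(c2)B(O)OC3)cc1` gives 19900 nM. Compound 3 `O=C(/C=C/c1ccc2c(c1)B(O)OC2)c1ccccc1O` gives 53700 nM, which is the highest of the three numbers: the gap a 6.5-fold higher number from compound 1 to compound 3 (0.81 log units; beyond the scatter) and the gap a 2.7-fold higher number from compound 2 to compound 3 (0.43 log units; beyond the scatter) both lie beyond the scatter, as does a 2.4-fold higher number from compound 1 to compound 2 (0.38 log units; beyond the scatter).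

Compound 4 `O=C(/C=C/c1ccc2c(c1)B(O)OC2)c1cccc(O)c1` has not been measured. It differs from compound 3 by 3-hydroxyphenyl in place of 2-hydroxyphenyl on a carbonyl carbon. Going by the values given here, this is a rearrangement within the same group rather than an exchange for a different one, and no measured pair shows that kind of change. The measured steps all exchange the whole aryl group on the carbonyl carbon or swap one substituent for another; they moved this assay by modest amounts only, and the step from compound 3 to compound 4 is a smaller alteration than any of them. The expectation is therefore a step within or near the scatter, with no clear direction, so a 1.2-fold lower number from compound 3 to compound 4 (0.08 log units; within the scatter) is the estimated move.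

Compound 4 is accordingly expected to give about 45000 nM in this assay, within a range from 15000 nM to 130000 nM.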

Compound 4, half-maximal inhibitory concentration: 25300 nM
Compound 4: the middle estimate sits 1.8-fold (0.25 log units) above what was measured; the measured number falls inside the stated range.
By their numbers in this assay, from the lowest: compound 1; then compounds 2 and 4 (each within the scatter of the next); then compound 3.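

In this assay, going by these compounds alone, relocating the hydroxyl on the aryl group at the carbonyl carbon is enough on its own to move the number, a 2.1-fold lower number from compound 3 to compound 4 (0.33 log units; beyond the scatter), although the atoms and the counted donors and acceptors stay the same; the earlier steps all exchanged one aryl group for another and could not show this. With the 3-hydroxyphenyl group the series no longer separates a hydroxyl-bearing aryl group from the 4-aminophenyl group, a 1.3-fold higher number from compound 2 to compound 4 (0.10 log units; within the scatter), so the wide gap seen with the 2-hydroxyphenyl group does not belong to every hydroxyphenyl group, while the 4-methylphenyl group still gives a clearly lower number, a 3.0-fold higher number from compound 1 to compound 4 (0.48 log units; beyond the scatter). No evidence at hand bears on why the two hydroxyphenyl groups differ.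

The compounds shown leave open where 4-hydroxyphenyl would fall relative to the two hydroxyphenyl groups here, and so whether the number follows any trend as the hydroxyl moves around the ring. They also leave open whether 2-methoxyphenyl and 3-methoxyphenyl, which carry a methyl on that oxygen, would repeat the same gap.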